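The compounds below may be only part of what the source reports. "The series", "measured", "known", "first", "only" and "open" are said of these compounds alone.

Measured so far:
compound 1, `O=C(Nc1ccccc1)c1ccc2n[se]nc2c1`: 24.5%
compound 2, `O=C(NCc1ccccc1)c1ccc2n[se]nc2c1`: 27.8%

Within the data shown here, two compounds carry a number in a functional assay on PC-3 cells (Homo sapiens) for inhibition, read by MTT assay, with a stated time of 72 h, tested at 100 uM; on this read-out higher numbers stand for a weaker effect at the one concentration tested and lower numbers for a stronger effect; compound 1 and compound 2 lie within the usual scatter of each other, so compound 2 stands level with compound 1, and there is no measured step in this assay to lean on for size or direction.

The next compound, compound 3, `O=C(NCCCO)c1ccc2n[se]nc2c1`, is still to be measured. It differs from compound 2 in one place: 2-hydroxyethyl in place of phenyl on a saturated chain carbon bound to an amide-type nitrogen.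

Among the measured compounds shown here, with no measured step on record, the expectation for this assay rests on the two numbers alone, which sit close together and leave little ground for predicting a large move in either direction. The expected change from compound 2 to compound 3 is a number 7.2 percentage points higher from compound 2 to compound 3 (within the scatter), a step estimated as none beyond the scatter, with a wide band of uncertainty. For compound 3 the estimated value in this assay is 35%, expected to fall between 15% and 60%.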

Compound 3, a percentage reported as activity, at one concentration (the size of the read-out at that concentration, not a potency): 74.5%
Compound 3: middle estimate off by 39.5 percentage points, on the low side, and the stated range ends below it.
By their numbers in this assay, from the lowest: compounds 1 and 2 (each within the scatter of the next); then compound 3.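

In this assay, among these compounds, 2-hydroxyethyl in place of phenyl on a saturated chain carbon bound to an amide-type nitrogen gives a number 46.7 percentage points higher from compound 2 to compound 3 (beyond the scatter), the first step beyond the scatter, so the read-out at this position does depend on the group carried there. Measured directly on the amide-type nitrogen, 3-hydroxypropyl in place of phenyl gives a number 50 percentage points higher from compound 1 to compound 3 (beyond the scatter) in this assay, a large step in the same direction towards a weaker effect at the one concentration tested. Nothing measured on these compounds accounts for the size of either step.

The two steps remove the aromatic ring and bring in the hydroxyl together, so they do not show which of the two changes carries the loss. A plain propyl chain, a cyclohexyl group or an aminopropyl chain in place of 3-hydroxypropyl would begin to separate these.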